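A few compounds are considered here, and "the series" means these few. Any claim that something is new, unique, unknown or untested is made for them only; others in the source may bear on it.

Measured so far in an ADME assay on Vero cells (Chlorocebus sabaeus) for cytotoxicity, read by trypan blue exclusion; a lower number here means that less compound is tolerated, a higher number that more compound is tolerated:
- compound 1 `CCn1nc(C(F)(F)F)cc1C(=O)Nc1ccc(S(=O)(=O)N2CCCCC2C)cc1`: "not determined" (no result reported)
- compound 2 `COC(=O)c1ccccc1-n1nc(C(F)(F)F)cc1C(=O)Nc1ccc(S(=O)(=O)N2CCCC2)cc1`: > 300000 nM

Compound 1 offers no result to work from. Compound 2 gives > 300000 nM, which is a limit of the assay and not a number. The only reference point is therefore (the limit of > 300000 nM in this assay, at which 1 of the 2 values shown sits).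

Compound 3 `O=C(O)c1ccccc1-n1nc(C(F)(F)F)cc1C(=O)Nc1ccc(S(=O)(=O)N2CCCC2)cc1` differs from compound 2 in one place: hydrogen in place of methyl on an oxygen next to a carbonyl group. This is hydrogen in place of methyl on an oxygen next to a carbonyl group, or methoxycarbonyl to carboxy. Among the compounds with values here, no pair of measured compounds provides a step to compare with, so the expectation for this assay is no step beyond the scatter, in either direction. That expectation rests only on the limit of compound 2, > 300000 nM.

The expected change is a number no higher from compound 2 to compound 3 (the limit leaves the size open). A limit rather than a number is the more likely report for compound 3. The estimated value for compound 3 is 300000 nM, with an expected range of 120000 nM to 500000 nM.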

Compound 3, half-maximal cytotoxic concentration: > 300000 nM
Compound 3: only a limit was reported; the forecaster's own chance of this, stated with the estimate: 80%; the middle value sits exactly at the limit.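

In this assay compound 3 gives > 300000 nM, a limit of the assay and not a number. Compound 2 is also reported only as a limit, so no step can be read between compound 2 and compound 3. The compounds shown leave open whether methoxycarbonyl to carboxy changes tolerated concentration in this assay at all.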